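The source may hold more compounds than are shown below. What is called first, only, known or untested is meant among the compounds shown, and "the series" means these compounds.

Measured compounds:
Compound 1 `COc1cccc(Cc2sc3c(c2C(=O)N[C@@H](C)c2ccc(C(=O)O)cc2)CCOC3)c1`: in a functional assay on CHO/Galpha16 cells for antagonist activity at prostaglandin E2 receptor EP4 subtype (Homo sapiens), read by calcium flux, with a stated time of 15 min (on this read-out lower numbers stand for stronger inhibition and higher numbers for weaker inhibition), compound 1 gives 1.9 nM.
Compound 2 `O=C(NCC1CCC(C(=O)O)CC1)c1c(Cc2ccc(F)cc2)sc2c1CCOC2`: in this assay compound 2 gives 30.3 nM.
Compound 3 `COC(=O)c1ccc([C@H](C)NC(=O)c2c(Cc3ccc(F)cc3)sc3c2CCOC3)cc1`: in this assay compound 3 gives > 1000 nM, which is a limit of the assay and not a number.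

Compound 1 has the lowest of the two numbers that were actually obtained. The nearest number belongs to compound 2, which sits higher, and that gap is beyond the usual scatter of repeated measurements. For compound 3 the assay reports only (the limit of > 1000 nM in this assay, at which 1 of the 3 values shown sits), so its value cannot be placed against the others.

The unmeasured compound 4 `C[C@H](NC(=O)c1c(C#Cc2ccc(F)cc2)sc2c1CCOC2)c1ccc(C(=O)O)cc1` differs from compound 1 in a single place: 2-(4-fluorophenyl)ethynyl in place of 3-methoxybenzyl on an aromatic carbon. Going by the values given here, no pair of measured compounds shows this kind of change, so the size of the step can only be judged from the three values given, and the acid and the rest of the shared core are kept unchanged.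

The expected step of a 6.3-fold higher number from compound 1 to compound 4 (0.80 log units; beyond the scatter) is a modest rise in the number, that is, somewhat weaker inhibition, with its lower end still inside the scatter of compound 1. Compound 4 is therefore estimated at 12 nM, with a likely range from 2.5 nM to 120 nM.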

Compound 4, half-maximal inhibitory concentration: 15.8 nM
Compound 4: the middle estimate sits 1.3-fold (0.12 log units) below what was measured; the range from low to high includes it.
By their numbers in this assay, from the lowest: compound 1; then compounds 4 and 2 (each within the scatter of the next). At a limit, above all of these: compound 3.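

Replacing 3-methoxybenzyl with 2-(4-fluorophenyl)ethynyl, on the aromatic carbon next to the ring sulfur, gives an 8.3-fold higher number from compound 1 to compound 4 (0.92 log units; beyond the scatter) in this assay, so this position does respond to the group it carries, though only modestly. Inhibition is weakened but not lost, since compound 4 still gives 15.8 nM, which shows that this position accepts a triple bond in the link to the aromatic ring. Both groups have the same number of heavy atoms and one carbon ring each, but the link and the ring substituent change together, and nothing measured here gives a cause for the step.

The compounds shown leave open whether the link or the ring substituent accounts for the step, and a 2-(3-methoxyphenyl)ethynyl group on the same carbon would separate the two. Also open, going by these compounds, is how this position would respond to a group with no aromatic ring at all, such as a longer alkyl chain or an amine.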